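Swapping the tetrahydroisoquinoline side group on compound 1

The source may report more compounds than this note shows. Statements on the series, on what has been measured and on what is new or still open speak of the compounds shown alone.

Compound 1 `c1ccc2c(c1)CN[C@@H](CN(CCCN1CCNCC1)[C@H]1CCCc3cccnc31)C2`: 100%
Compound 2 `c1ccc2c(c1)CN[C@@H](CN(CCN1CCNCC1)[C@H]1CCCc3cccnc31)C2`: 62%
Compound 3 `NC(=O)N1CCN(CCCN(C[C@H]2Cc3ccccc3CN2)[C@H]2CCCc3cccnc32)CC1`: 4%

In an ADME assay on microsomes from liver (Rattus norvegicus) for metabolic stability, read by LC-MS, with a stated time of 10 min, tested at 0.5 uM (a lower number here means that less of the compound is left, a higher number that more of the compound is left), compound 1 stands highest of the three, at 100%. Compound 4 `c1cnc(CN(CCCN2CCNCC2)[C@H]2CCCc3cccnc32)nc1` has not been measured, and its structural change is pyrimidin-2-yl in place of 1,2,3,4-tetrahydroisoquinolin-3-yl on a saturated chain carbon bound to an amine nitrogen. For the measured compounds named here, no measured step touches this place, so the evidence is indirect. Changes elsewhere gave large steps beyond the scatter: a number 38 percentage points lower from compound 1 to compound 2 (beyond the scatter) and a number 96 percentage points lower from compound 1 to compound 3 (beyond the scatter). These show that the read-out can fall sharply among these compounds, but they do not size this replacement. With compound 1 at 100%, a moderate fall is expected. The expected step is a number 25 percentage points lower from compound 1 to compound 4 (beyond the scatter). For compound 4 the estimated value is 75%, with an expected range of 40% to 100%.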

Compound 4, percent of the compound remaining: 68%
For compound 4 the middle estimate is 7 percentage points above the measured one; the measured number falls inside the stated range.
By their numbers in this assay, from the lowest: compound 3; then compounds 2 and 4 (each within the scatter of the next); then compound 1.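

In this assay, for the compounds shown here, pyrimidin-2-yl in place of 1,2,3,4-tetrahydroisoquinolin-3-yl gives a number 32 percentage points lower from compound 1 to compound 4 (beyond the scatter), so this place, on a saturated chain carbon bound to an amine nitrogen, also moves the read-out, which the earlier steps elsewhere could not show. The group that leaves carries a hydrogen-bond donor and a defined stereocentre and the group that enters carries neither, so this single step cannot be tied to either feature.

On these data alone, whether a phenyl or a piperidin-3-yl group at this place would keep more of the compound remaining stays open. Nothing measured here explains the step.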